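Benzyloxy to methoxy: working notes on the series

The source may report more compounds than this note shows. Statements on the series, on what has been measured and on what is new or still open speak of the compounds shown alone.

In a functional assay on ileum (Cavia porcellus) for antagonist activity, with a stated time of 30 s (on this read-out higher numbers stand for weaker inhibition and lower numbers for stronger inhibition), compound 1 (`O=C(O)c1cc(=O)c2ccc(OCCCCCc3ccccc3)cc2o1`) gives 0.6 ug/mL and compound 2 (`O=C(O)c1cc(=O)c2ccc(OCCCCCOc3cccc(OCc4ccccc4)c3)cc2o1`) gives 1 ug/mL on the same scale. For the measured compounds named here, these two values lie within the scatter of each other, so compound 2 stands level with compound 1 on the numbers so far.

Compound 3 (`COc1cccc(OCCCCCOc2ccc3c(=O)cc(C(=O)O)oc3c2)c1`) has not yet been measured. It departs from compound 2 by one change (hydrogen in place of phenyl on a saturated chain carbon bound to an oxygen on an aromatic ring): hydrogen in place of phenyl on a saturated chain carbon bound to an oxygen on an aromatic ring, which also reads as benzyloxy to methoxy.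

Going by the values given here, no measured pair isolates this change. Among the compounds with values here, the only guide is that compound 2 at 1 ug/mL and compound 1 at 0.6 ug/mL do not separate although their chain ends differ. A small move toward weaker inhibition in this assay is expected, with no shift beyond the scatter. The estimated step is a 1.5-fold higher number from compound 2 to compound 3 (0.18 log units; within the scatter) and stays within the scatter. For compound 3 the estimated value is 1.5 ug/mL with an expected range of 0.4 ug/mL to 5 ug/mL for the coming measurement.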

Compound 3, half-maximal inhibitory concentration: 1.5 ug/mL
Compound 3: the middle estimate sits on the measured number at the digits printed, within the range that was stated.
By their numbers in this assay, from the lowest: compounds 1, 2 and 3 (each within the scatter of the next, the first and the last beyond it).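

The benzyloxy group of compound 2 can be cut back to methoxy with little consequence in this assay: hydrogen in place of phenyl on a saturated chain carbon bound to an oxygen on an aromatic ring gives a 1.5-fold higher number from compound 2 to compound 3 (0.18 log units; within the scatter), so on these numbers the outer phenyl ring is not needed to stay level with compound 2. At the end of the chain, 3-methoxyphenoxy in place of phenyl on a saturated chain carbon, five bonds along the chain from an oxygen on an aromatic ring, gives a 2.5-fold higher number from compound 1 to compound 3 (0.40 log units; beyond the scatter), a modest step and the only one in this set that lies beyond the scatter, which makes this chain end the first place in the series where a change registers on this read-out. Nothing measured alongside these numbers speaks to what lies behind the size of either step.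

Still open, as far as these compounds go, is whether the same place tolerates a group of another kind, such as an amine or a carboxylic acid in place of the methoxy. Also open, from the compounds shown here alone, is whether either step holds on a longer chain or with a changed shared core.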